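The source may hold more compounds than are shown below. What is called first, only, known or untested is meant among the compounds shown, and "the series" means these compounds.

Compound 2 `N#Cc1c(N)nc(SCc2csc(-c3ccc(Cl)cc3)n2)nc1-c1ccccc1` gives 8.9 nM in an assay on CHO cells for displacement of a labelled ligand from adenosine receptor A1 (Homo sapiens), read by scintillation counting, with a stated time of 1 h; on this read-out lower numbers stand for stronger inhibition and higher numbers for weaker inhibition. Its one companion, compound 1 `CC(=O)Nc1ccc(-c2nc(SCc3csc(-c4ccc(Cl)cc4)n3)nc(N)c2C#N)cc1`, gives 14 nM in this assay, and the step of a 1.6-fold lower number from compound 1 to compound 2 (0.20 log units; within the scatter) leaves the two within the scatter of each other. Compound 3 `N#Cc1c(N)nc(SCc2csc(-c3ccc(Cl)cc3)n2)nc1-c1ccc(O)cc1` differs from compound 2 by hydroxy in place of hydrogen on an aromatic carbon, on the same aromatic carbon that bears acetamido in compound 1. Within the data shown here, that single measured step, acetamido to hydrogen, is the only guide here, and it changed little. For compound 3 the expected step is therefore small, a 1.0-fold higher number from compound 2 to compound 3 (0.00 log units; within the scatter). Compound 3 is estimated at 9 nM, within a range from 3 nM to 30 nM.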

Compound 3, inhibition constant: 15 nM
Compound 3: middle estimate off by 1.7-fold (0.22 log units), on the low side, and the stated range covers the measured number.
By their numbers in this assay, from the lowest: compounds 2, 1 and 3 (each within the scatter of the next).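

In this assay, the step of a 1.7-fold higher number from compound 2 to compound 3 (0.23 log units; within the scatter) and the step of a 1.1-fold higher number from compound 1 to compound 3 (0.03 log units; within the scatter) both stay within the scatter. Hydroxy on this aromatic carbon, para to a large group, therefore cannot be told apart from hydrogen or acetamido, so three different groups at this place now give matching results. Nothing measured here offers an explanation for this. Still open, from the compounds shown here alone, is whether an amine, a carboxylic acid or a methoxy group at this place would move the number beyond the scatter.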